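From Pyridin-3-yl to Pyridin-2-yl in a Small Inhibitor Set

A few compounds are considered here, and "the series" means these few. Any claim that something is new, unique, unknown or untested is made for them only; others in the source may bear on it.

Of the compounds shown here, three have so far been measured in a functional assay for inhibition, read by spectrophotometry; a higher number here means a weaker inhibitor, a lower number a stronger inhibitor. Compound 1 (`N/C(=N\OS(=O)(=O)c1ccc([N+](=O)[O-])cc1)c1ccc([N+](=O)[O-])cc1`) gives 66500 nM, compound 2 (`N/C(=N\OS(=O)(=O)c1ccc([N+](=O)[O-])cc1)c1cccnc1`) gives 85000 nM, and compound 3 (`CCCCCCCCCCCCCCCCS(=O)(=O)O/N=C(\N)c1cccnc1`) gives 70000 nM. Compound 2 therefore stands level with the other two: its gaps to compound 1 and to compound 3 both lie within the usual scatter of repeated measurements, so these numbers set no order among the three.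

The next compound to be measured is compound 4 (`N/C(=N\OS(=O)(=O)c1ccc([N+](=O)[O-])cc1)c1ccccn1`), which has the same atoms as compound 2, joined differently: pyridin-2-yl in place of pyridin-3-yl on a carbon with a double bond to nitrogen. The change is confined to one place, on a carbon with a double bond to nitrogen, and the rest of the structure stays as it is. Going by the values given here, no step between measured compounds is available as a guide, so the data show nothing directly about what this swap does. Among the compounds with values here, the only anchor is compound 2 at 85000 nM, together with the close grouping of all three measured values. On that basis the expected change, a 1.1-fold lower number from compound 2 to compound 4 (0.05 log units; within the scatter), is none beyond the scatter, and no direction is favoured. For compound 4 the estimated value in this assay is 75000 nM, with an expected range from 30000 nM to 170000 nM.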

Compound 4, half-maximal inhibitory concentration: 72000 nM
For compound 4 the middle estimate is 1.0-fold (0.02 log units) above the measured one; the measured number falls inside the stated range.
By their numbers in this assay, from the lowest: compounds 1, 3, 4 and 2 (each within the scatter of the next).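

With this pair the set gains its first step that changes one place only: pyridin-2-yl in place of pyridin-3-yl on a carbon with a double bond to nitrogen. In this assay that step reads a 1.2-fold lower number from compound 2 to compound 4 (0.07 log units; within the scatter) and so leaves the two compounds level, even though their atoms are joined differently. With the rest of the structure held fixed, the choice between these two groups at this place therefore produces no difference that stands clear of repeated measurement, and no other data bear on this result.

Going by these compounds, whether the same holds for other groups at this place stays open, such as pyridin-4-yl, a plain phenyl ring or a phenyl ring carrying a carboxylic acid or an amine. On these data alone, it is equally open whether the swap would stay as flat on the core of compound 3 with its long chain, since this single pair speaks only for the core shared by compound 2 and compound 4.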